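This account rests on a few compounds, and the source may have more. Where it says the series, first, only, none or still open, it means among the compounds named here.

Measured so far in a functional assay on MT4 cells (Homo sapiens) for cytotoxicity, read by MTT assay; a lower number here means that less compound is tolerated, a higher number that more compound is tolerated:

compound 1 `Cc1c(O)nc(SCc2ccc(C#N)cc2)nc1Cc1c(Cl)cccc1Cl`: > 60000 nM
compound 2 `COc1ccc(CCSc2nc(Cc3c(Cl)cccc3Cl)c(C)c(=O)[nH]2)cc1`: > 57000 nM
compound 3 `Cc1c(O)nc(SCc2ccc(C#N)cc2)nc1Cc1c(F)cccc1F`: > 65000 nM

All three entries are limits and not numbers. Compound 1 therefore stands with only its limit of > 60000 nM, and no number can be placed on it.

Compound 4 `Cc1c(O)nc(SCc2ccc([N+](=O)[O-])cc2)nc1Cc1c(Cl)cccc1Cl` keeps the rest of compound 1 and carries nitro in place of cyano on an aromatic carbon, para to a large group: nitro in place of cyano on an aromatic carbon.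

Going by the values given here, only one measured step leaves compound 1, and it changes a different group: a step that the two limits leave unreadable from compound 1 to compound 3. Among the compounds with values here, its size cannot be read, and no measured step concerns the cyano group itself. The data therefore give no ground for a step beyond the scatter in this assay, and they favour no direction.

The expected step is an at least 1.2-fold lower number from compound 1 to compound 4 (0.07 log units; that floor lies within the scatter), which is an estimate that stays within the scatter. For compound 4 the estimated value is 50000 nM, with an expected range of 15000 nM to 100000 nM.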

Compound 4, half-maximal cytotoxic concentration: > 58000 nM
Compound 4: no number, only a limit (the forecaster's own chance of this, stated with the estimate: 65%); middle value at least 1.1-fold (0.06 log units) away from the limit.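

In this assay compound 4 gives > 58000 nM, which is a limit and not a number. Compound 1 also stands only as a limit, and the step between compound 1 and compound 4 cannot be read. The compounds shown leave open whether nitro and cyano differ at all in this assay.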